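Nitrobenzyl positional swap on the cyclic phosphate series

The source may report more compounds than this note shows. Statements on the series, on what has been measured and on what is new or still open speak of the compounds shown alone.

Compound 3 `Nc1ncnc2c1ncn2[C@@H]1O[C@@H]2CO[P@@](=O)(OCc3ccc([N+](=O)[O-])cc3)O[C@H]2[C@H]1O` gives 3 h in a physicochemical assay for metabolic stability, at 30 degrees C, at pH 6.5 (on this read-out lower numbers stand for a shorter-lived compound and higher numbers for a longer-lived compound), level with compound 2 `Nc1ncnc2c1ncn2[C@@H]1O[C@@H]2CO[P@@](=O)(OCc3ccccc3)O[C@H]2[C@H]1O`, which gives 3 h; together these are the lowest of the three numbers measured, and compound 1 `Nc1ncnc2c1ncn2[C@@H]1O[C@@H]2CO[P@](=O)(OCc3ccccc3[N+](=O)[O-])O[C@H]2[C@H]1O`, which gives 9.5 h, stands furthest away. The step from compound 2 to compound 3 was no change at the digits printed from compound 2 to compound 3 (within the scatter), so the nitro group in that position left the half-life unchanged.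

Compound 4 `Nc1ncnc2c1ncn2[C@@H]1O[C@@H]2CO[P@@](=O)(OCc3ccccc3[N+](=O)[O-])O[C@H]2[C@H]1O` differs from compound 3 by 2-nitrophenyl in place of 4-nitrophenyl on a saturated chain carbon bound to an oxygen. Going by the values given here, the only measured step, from compound 2 to compound 3, concerns a nitro group added rather than moved, so it bears on the change only indirectly and argues for a small effect. Compound 1 carries the same 2-nitrobenzyl group but differs from compound 4 in another place as well, so its higher value is only a loose pointer. A modest upward step is expected, a 1.7-fold higher number from compound 3 to compound 4 (0.22 log units; within the scatter), and compound 4 is estimated at 5 h, within 2.5 h to 10 h.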

Compound 4, half-life: 3 h
Compound 4: the middle estimate sits 1.7-fold (0.22 log units) above what was measured; the range from low to high includes it.
By their numbers in this assay, from the lowest: compounds 2, 3 and 4 (each within the scatter of the next); then compound 1.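

Within the drawn R series at phosphorus, the place of the nitro group does not register: going from 4-nitrobenzyl to 2-nitrobenzyl gives no change at the digits printed from compound 3 to compound 4 (within the scatter). The 2-nitrobenzyl group also leaves the half-life where the unsubstituted benzyl group has it, with no change at the digits printed from compound 2 to compound 4 (within the scatter), so neither nitro placement separates from hydrogen on the aromatic carbon. The one step beyond the scatter in this assay is a 3.2-fold lower number from compound 1 to compound 4 (0.50 log units; beyond the scatter), which places the gap with the same group at the phosphorus stereocentre, drawn S in the longer-lived compound, because of this: the fact that compounds 1 and 4 differ only in the configuration as drawn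

Whether the drawn S configuration carries the same gain with benzyl or 4-nitrobenzyl remains open, as only the 2-nitrobenzyl group is shown in that form. Also open, from the compounds shown here alone, is how an amine on the aromatic ring, or a longer chain in place of benzyl, would behave in either configuration.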